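Replacing a Hydroxyphenyl Ether With a Methylphenyl Ether

A few compounds are considered here, and "the series" means these few. Any claim that something is new, unique, unknown or untested is made for them only; others in the source may bear on it.

Compound 1 `O=C1OCCN1C(=O)c1ccc(Oc2cccc(Cl)c2)cc1`, 7740 nM in an assay on HEK293 cells for inhibition of N-acylethanolamine-hydrolyzing acid amidase (Rattus norvegicus), read by LC-MS, with a stated time of 30 min; a higher number here means a weaker inhibitor, a lower number a stronger inhibitor.
Compound 2 `O=C1OCCN1C(=O)c1ccc(Oc2ccc(O)cc2)cc1`, > 20000 nM in this assay.

Compound 2 reaches only the limit of this assay; its > 20000 nM is a limit, not a number (the limit of > 20000 nM in this assay, at which 1 of the 2 values shown sits). Compound 3 `Cc1cccc(Oc2ccc(C(=O)N3CCOC3=O)cc2)c1` differs from compound 2 by 3-methylphenyl in place of 4-hydroxyphenyl on an oxygen on an aromatic ring. Among the compounds with values here, the one measured step bearing on this is an at least 2.5-fold higher number from compound 1 to compound 2 (0.41 log units; beyond the scatter), which runs the opposite way, from a substituted phenyl toward the hydroxyphenyl. Reversing that kind of change, the expected step of an at least 2.2-fold lower number from compound 2 to compound 3 (0.34 log units; beyond the scatter) should lower the number for compound 3 beyond the scatter. Compound 3 is therefore estimated at 9000 nM, between 3000 nM and 20000 nM.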

Compound 3, half-maximal inhibitory concentration: 5210 nM
Estimate against measurement, compound 3: 1.7-fold (0.24 log units) above, and the stated range covers the measured number.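

On the oxygen on an aromatic ring, 3-methylphenyl in place of 4-hydroxyphenyl gives an at least 3.8-fold lower number from compound 2 to compound 3 (0.58 log units; beyond the scatter). The value of compound 2 is a limit, not a number: the limit of > 20000 nM in this assay, at which 1 of the 3 values shown sits. Methyl in place of chloro on an aromatic carbon gives a 1.5-fold lower number from compound 1 to compound 3 (0.17 log units; within the scatter), so these two groups cannot be told apart here.

The step from 4-hydroxyphenyl to 3-methylphenyl changes both the group and its place on the ring, and the compounds shown do not separate the two. Going by these compounds, a 3-hydroxyphenyl, a 4-methylphenyl or a phenyl bearing an amine remains open.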